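A few compounds are considered here, and "the series" means these few. Any claim that something is new, unique, unknown or untested is made for them only; others in the source may bear on it.

Compound 1 `CN/N=C/c1ccc2ccc(=O)oc2c1` and compound 2 `CO/N=C/c1ccc2ccc(=O)oc2c1` share one core. In a functional assay for inhibition of beta-glucuronidase (Bos taurus), tested at 1 mM (a lower number here means a weaker effect, a higher number a stronger effect of the compound at the concentration tested), compound 1 gives 93.3%, and compound 2 gives 94.1%; the step of a number 0.8 percentage points higher from compound 1 to compound 2 (within the scatter) lies within the scatter. Compound 2 holds the higher of the two numbers, yet the gap to compound 1 is within the scatter. Compound 3 `O=c1ccc2ccc(/C=N/O)cc2o1` differs from compound 2 by hydrogen in place of methyl on an oxygen. For the measured compounds named here, the only measured step, a number 0.8 percentage points higher from compound 1 to compound 2 (within the scatter), exchanged the group on the double-bonded nitrogen without effect beyond the scatter, so a move of no more than a number 4.1 percentage points lower from compound 2 to compound 3 (within the scatter) is expected from this change too. Compound 3 is therefore estimated at 90%, between 78% and 97%.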

Compound 3, a percentage reported as inhibition, at one concentration (the size of the read-out at that concentration, not a potency): 100%
The estimate for compound 3 lay 10 percentage points below the measured number; the measured number lies above the stated range.
By their numbers in this assay, from the lowest: compounds 1, 2 and 3 (each within the scatter of the next).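

In this assay the hydroxy group reads level with methoxy, with a number 5.9 percentage points higher from compound 2 to compound 3 (within the scatter), and level with methylamino, with a number 6.7 percentage points higher from compound 1 to compound 3 (within the scatter). The position on the double-bonded nitrogen therefore tolerates the loss of the methyl as well as the exchange of methylamino at this single concentration, with all three compounds within the scatter of one another. No measurement on hand explains this result. From the compounds shown here alone, whether a longer chain such as benzyloxy, or an acetyl group on that oxygen, would lower the read-out stays open. Going by these compounds, whether any of the three compounds has a stronger or weaker effect at this concentration also stays open.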